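Lengthening the chain to the dimethylpiperazine of compound 1

The compounds below may be only part of what the source reports. "The series", "measured", "known", "first", "only" and "open" are said of these compounds alone.

Compound 1 `Cc1cc(C(=O)N[C@H]2CC[C@@H](NC(=O)c3cc(F)cnc3Oc3cccc(-c4ccc(CN5C[C@@H](C)N[C@@H](C)C5)cc4)c3)CC2)nn1C` gives 0.11 here
Compound 2 `C[C@@H]1CN(Cc2ccc(-c3cccc(Oc4ncc(F)cc4C(=O)N[C@H]4CC[C@@H](NC(=O)c5cc6ccccn6n5)CC4)c3)cc2)C[C@H](C)N1` gives 0.045 here

Going by the values given here, in an ADME assay on a cell-free system (plasma, Homo sapiens) for protein binding (on this read-out lower numbers stand for a smaller free fraction and higher numbers for a larger free fraction), compound 1 reads 0.11 and holds the higher of the two numbers measured so far. Compound 3 `Cc1cc(C(=O)N[C@H]2CC[C@@H](NC(=O)c3cc(F)cnc3Oc3cccc(-c4ccc(CCCN5C[C@@H](C)N[C@@H](C)C5)cc4)c3)CC2)nn1C` keeps the core of compound 1 and differs in one place: 2-(3,5-dimethylpiperazin-1-yl)ethyl in place of 3,5-dimethylpiperazin-1-yl on a saturated chain carbon bound to an aromatic carbon on that same spot. In words, 2-(3,5-dimethylpiperazin-1-yl)ethyl stands in place of 3,5-dimethylpiperazin-1-yl on a saturated chain carbon bound to an aromatic carbon. Among the compounds with values here, the only measured step is a 2.4-fold lower number from compound 1 to compound 2 (0.39 log units; beyond the scatter) and it concerns a group on a carbonyl carbon, not this chain. It therefore shows only how far one change can move this number. Expected here is a 1.2-fold lower number from compound 1 to compound 3 (0.09 log units; within the scatter) and thus nothing beyond the scatter. For compound 3 the estimated value is 0.09 with an expected range from 0.05 to 0.16 in this measurement.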

Compound 3, unbound fraction: 0.045
For compound 3 the middle estimate is 2.0-fold (0.30 log units) above the measured one; the measured number lies below the stated range.
By their numbers in this assay, from the lowest: compounds 2 and 3 (each within the scatter of the next); then compound 1.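

The chain that carries the dimethylpiperazine is not a silent spot in this assay: going from (3,5-dimethylpiperazin-1-yl)methyl to 3-(3,5-dimethylpiperazin-1-yl)propyl gives a 2.4-fold lower number from compound 1 to compound 3 (0.39 log units; beyond the scatter), so the free fraction drops. The piperazine ring, its hydrogen-bond donor and acceptors and its two defined stereocentres count the same on both sides, which leaves the extra chain length as the only difference between these two compounds. Nothing available here explains why a longer chain goes with this lower number.

The compounds shown leave open whether a still longer chain, such as a butyl chain ending in the same piperazine, would lower the number further. They also leave open whether the same lengthening would act alike with another amine at the chain end, such as morpholine.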